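Propyl Amide in Place of the Methylbenzyl Amide of Compound 1

This account rests on a few compounds, and the source may have more. Where it says the series, first, only, none or still open, it means among the compounds named here.

Compound 1 `C=CC1=C(C(=O)NCc2ccc(C)cc2)C(c2ccc(OC)cc2)OC1` in a functional assay on A549 cells (Homo sapiens) for cytotoxicity, read by MTT assay, with a stated time of 24 h (on this read-out lower numbers stand for stronger inhibition and higher numbers for weaker inhibition), gives > 100000 nM, which is a limit of the assay and not a number.
Compound 2 `C=CC1=C(C(=O)NCc2ccc(C)cc2)C(c2ccc(F)cc2)OC1` gives > 100000 nM, again a limit.
Compound 3 `C=CC1=C(C(=O)NCc2ccc(C)cc2)C(c2ccc(OC)c(OC)c2)OC1` gives > 100000 nM, also a limit.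

Compound 1 therefore stands only at a limit, as do its two companions (the limit of > 100000 nM in this assay, at which 3 of the 3 values shown sit). The two measured steps from it, a step that the two limits leave unreadable from compound 1 to compound 2 and a step that the two limits leave unreadable from compound 1 to compound 3, have no readable size. Compound 4 `C=CC1=C(C(=O)NCCC)C(c2ccc(OC)cc2)OC1` differs from compound 1 by ethyl in place of 4-methylphenyl on a saturated chain carbon bound to an amide-type nitrogen. Neither measured step touches this part of the molecule, and neither carries a size, so no direction can be drawn from them; the expected step is a step that the limit leaves unreadable from compound 1 to compound 4. Compound 4 is estimated at 150000 nM, within 50000 nM to 500000 nM, with a limit the most probable outcome.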

Compound 4, half-maximal inhibitory concentration: > 100000 nM
Compound 4: a limit, no number (the forecaster's own chance of this, stated with the estimate: 85%); the middle value does not contradict the limit.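

Compound 4, like compound 1, stands only at a limit of the assay, so no step can be read between compound 1 and compound 4. The compounds shown leave open which structural change, if any, would give a measurable value in this assay.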